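This account rests on a few compounds, and the source may have more. Where it says the series, first, only, none or still open, it means among the compounds named here.

Values so far in a functional assay on HeLa cells (Homo sapiens) for inhibition, read by CCK-8 assay, with a stated time of 48 h (a lower number here means a stronger inhibitor, a higher number a weaker inhibitor), are these

- compound 1 `COc1cc(-c2ccnc3cc(-c4ccc(C)c(C)c4)nn23)cc(OC)c1OC` gives 241 nM
- compound 2 `COc1cc(-c2ccnc3cc(-c4ccc5cc[nH]c5c4)nn23)cc(OC)c1OC` gives 125 nM
- compound 3 `COc1ccc(-c2cc3nccc(-c4cc(OC)c(OC)c(OC)c4)n3n2)cc1F` gives 236 nM

These three compounds share one core and differ in a single group. Compound 3 at 236 nM cannot be ranked against the other two. Its steps are a 1.0-fold lower number from compound 1 to compound 3 (0.01 log units; within the scatter) and a 1.9-fold higher number from compound 2 to compound 3 (0.28 log units; within the scatter) and both lie within the scatter. The remaining step of a 1.9-fold lower number from compound 1 to compound 2 (0.29 log units; within the scatter) lies within it too.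

Compound 4 `COc1cc(-c2ccnc3cc(-c4ccc(C(C)(C)C)cc4)nn23)cc(OC)c1OC` has not yet been measured. It carries 4-(tert-butyl)phenyl in place of the 3-fluoro-4-methoxyphenyl of compound 3 on an aromatic carbon 4-(tert-butyl)phenyl in place of 3-fluoro-4-methoxyphenyl on an aromatic carbon of the five-membered ring. The three measured swaps at this same place gave no step beyond the scatter, and none of the three goes against that. None of them carries a 4-(tert-butyl)phenyl group, however, so the range has to stay wide. The expected change is a 1.2-fold higher number from compound 3 to compound 4 (0.07 log units; within the scatter) and so nothing beyond the scatter in either direction. For compound 4 the estimated value is 280 nM and the expected range runs from 110 nM to 800 nM in this measurement.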

Compound 4, half-maximal inhibitory concentration: > 10000 nM
Compound 4 was reported as a limit (the forecaster's own chance of this, stated with the estimate: 3%); middle value at least 35-fold (1.55 log units) away from the limit.
By their numbers in this assay, from the lowest: compounds 2, 3 and 1 (each within the scatter of the next). At a limit, above all of these: compound 4.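

In this assay compound 4 gives > 10000 nM, which is a limit of the assay and not a number: the limit of > 10000 nM in this assay, at which 1 of the 4 values shown sits.

Even so, the steps can be read as minimum sizes, and replacing the group at this position gives an at least 42-fold higher number from compound 3 to compound 4 (1.62 log units; beyond the scatter), an at least 80-fold higher number from compound 2 to compound 4 (1.90 log units; beyond the scatter) and an at least 41-fold higher number from compound 1 to compound 4 (1.61 log units; beyond the scatter). The earlier compounds shown here suggested that this aromatic carbon of the five-membered ring accepted different aromatic groups with no change beyond the scatter, but compound 4 shows that this does not hold for every group.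

The compounds shown do not reveal which feature of the 4-(tert-butyl)phenyl group goes with this loss of activity. On these data alone, it remains open whether a 4-methylphenyl, 4-isopropylphenyl or 4-aminophenyl group would behave like the groups of compounds 1, 2 and 3 or like that of compound 4.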